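The source may hold more compounds than are shown below. What is called first, only, known or untested is meant among the compounds shown, and "the series" means these compounds.

In an assay on isolated protein for inhibition of Aromatase (Homo sapiens), read by fluorescence and colorimetric assay, with a stated time of 30 min (a higher number here means a weaker inhibitor, a lower number a stronger inhibitor), compound 1 `CCCCCCCCCCc1cn(C(c2ccc(C#N)cc2)c2ccc(C#N)cc2)nn1` gives 16000 nM, compound 2 `N#Cc1ccc(C(c2ccc(C#N)cc2)n2cc(COc3ccccc3)nn2)cc1` gives 11000 nM, and compound 3 `N#Cc1ccc(OCc2cn(C(c3ccc(C#N)cc3)c3ccc(C#N)cc3)nn2)cc1` gives 4640 nM, the lowest number of the three. The two steps into compound 3 read a 3.4-fold lower number from compound 1 to compound 3 (0.54 log units; beyond the scatter) and a 2.4-fold lower number from compound 2 to compound 3 (0.37 log units; beyond the scatter), both beyond the scatter, while the step of a 1.5-fold lower number from compound 1 to compound 2 (0.16 log units; within the scatter) stayed within it. Compound 4 `N#Cc1ccc(C(c2ccc(C#N)cc2)n2cc(COc3ccc([N+](=O)[O-])cc3)nn2)cc1` differs from compound 3 by nitro in place of cyano on an aromatic carbon. For the measured compounds named here, the only measured step at this aromatic carbon is a 2.4-fold lower number from compound 2 to compound 3 (0.37 log units; beyond the scatter), from an unsubstituted ring to the nitrile; no measured step exchanges one group for another at the same place, so the size of such a swap is untested, and nothing measured points to a large move in either direction. The expected step is a 1.0-fold lower number from compound 3 to compound 4 (0.01 log units; within the scatter), which would leave compound 4 close to compound 3 and within the scatter. Compound 4 is therefore estimated at 4500 nM, with a range from 2000 nM to 10000 nM.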

Compound 4, half-maximal inhibitory concentration: 7730 nM
Compound 4: the middle estimate sits 1.7-fold (0.23 log units) below what was measured; low and high end bracket the measured number.
By their numbers in this assay, from the lowest: compounds 3, 4, 2 and 1 (each within the scatter of the next, the first and the last beyond it).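

Nitro in place of the nitrile at this aromatic carbon, para to a large group, is the first exchange of one group for another at this place, and it gives a 1.7-fold higher number from compound 3 to compound 4 (0.22 log units; within the scatter) in this assay, so the two groups are not separated here. Against hydrogen, nitro gives a 1.4-fold lower number from compound 2 to compound 4 (0.15 log units; within the scatter) and is not separated from the unsubstituted ring either, so the nitrile step from hydrogen, which lay beyond the scatter, finds no clear match in the nitro step. The 4-nitrophenoxy group still stands apart from nonyl, with a 2.1-fold lower number from compound 1 to compound 4 (0.32 log units; beyond the scatter) as a modest step, and no measured evidence accounts for any of these readings.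

From the compounds shown here alone, whether a methoxy group, an amine or a carboxylic acid at this place would read differently from the nitrile stays open. So does whether a shorter chain in place of nonyl would separate from the phenoxy compounds.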